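Amine swaps on a trimethoxystyryl thienopyrimidine core

A few compounds are considered here, and "the series" means these few. Any claim that something is new, unique, unknown or untested is made for them only; others in the source may bear on it.

Compounds measured so far:
- compound 1 `COc1cc(/C=C/c2nc(N3CCCC3)c3sccc3n2)cc(OC)c1OC` gives 681000 nM in a functional assay on L02 cells (Homo sapiens) for inhibition, read by Griess assay, with stated times of 1 h and 24 h; on this read-out higher numbers stand for weaker inhibition and lower numbers for stronger inhibition
- compound 2 `COc1cc(/C=C/c2nc(Nc3ccc(C(F)(F)F)cc3)c3sccc3n2)cc(OC)c1OC` gives 436000 nM in this assay
- compound 3 `COc1cc(/C=C/c2nc(N(C)c3ccccc3)c3sccc3n2)cc(OC)c1OC` gives 767000 nM in this assay

Compound 3 carries the highest of the three numbers, yet its separations are small: a 1.1-fold higher number from compound 1 to compound 3 (0.05 log units; within the scatter) and a 1.8-fold higher number from compound 2 to compound 3 (0.25 log units; within the scatter). Compound 4 `COc1cc(/C=C/c2nc(NCc3ccccc3Cl)c3sccc3n2)cc(OC)c1OC` differs from compound 3 in one place: (2-chlorobenzyl)amino in place of methyl(phenyl)amino on an aromatic carbon. For the measured compounds named here, no measured step copies this change. The nearest are the replacements at the same aromatic carbon, a 1.6-fold lower number from compound 1 to compound 2 (0.19 log units; within the scatter) and a 1.1-fold higher number from compound 1 to compound 3 (0.05 log units; within the scatter), each within the scatter. Compound 4 is therefore expected to give about 650000 nM, with a range from 300000 nM to 1400000 nM. The expected step from compound 3 is a 1.2-fold lower number from compound 3 to compound 4 (0.07 log units; within the scatter), not beyond the scatter.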

Compound 4, half-maximal inhibitory concentration: > 1000000 nM
Compound 4: only a limit was reported; the forecaster's own chance of this, stated with the estimate: 15%; middle value at least 1.5-fold (0.18 log units) from the limit.
By their numbers in this assay, from the lowest: compounds 2, 1 and 3 (each within the scatter of the next). At a limit, above all of these: compound 4.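

Compound 4 stands at a limit of this assay, not at a number: the limit of > 1000000 nM in this assay, at which 1 of the 4 values shown sits.

For the compounds shown here, at this aromatic carbon one step now clears the scatter, an at least 2.2-fold higher number from compound 2 to compound 4 (0.36 log units; beyond the scatter) and so (2-chlorobenzyl)amino is the first group here to part from another. The other two steps are an at least 1.3-fold higher number from compound 3 to compound 4 (0.11 log units; that floor lies within the scatter) and an at least 1.4-fold higher number from compound 1 to compound 4 (0.16 log units; that floor lies within the scatter) and neither floor adds a separation. Going by these compounds, how far the true value of compound 4 lies past its limit stays open. Also open, on these data alone, is whether a plain benzylamino group without the chlorine, or a morpholine at this carbon, would fall with compound 2 or with compound 4.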